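Methoxy position on the benzyl arm of the shared core

A few compounds are considered here, and "the series" means these few. Any claim that something is new, unique, unknown or untested is made for them only; others in the source may bear on it.

Going by the values given here, three benzyl variants of the shared core have numbers so far. Compound 1 `CCOC(=O)c1ccc(-c2nn(Cc3ccc(Cl)cc3)c3ccccc23)cc1` gives 120 nM in a functional assay on cells (Platelet, Homo sapiens) for inhibition; on this read-out higher numbers stand for weaker inhibition and lower numbers for stronger inhibition. Compound 2 `CCOC(=O)c1ccc(-c2nn(Cc3ccccc3OC)c3ccccc23)cc1` gives 470 nM in this assay, and compound 3 `CCOC(=O)c1ccc(-c2nn(Cc3cccc(OC)c3)c3ccccc23)cc1` gives 260 nM in this assay. Compound 3 therefore holds the second highest of the three numbers, separated from compound 2 by a step within the scatter and from compound 1 by a step beyond it. The step of a 3.9-fold higher number from compound 1 to compound 2 (0.59 log units; beyond the scatter) and the step of a 2.2-fold higher number from compound 1 to compound 3 (0.34 log units; beyond the scatter) both go toward weaker inhibition when a methoxyphenyl replaces the 4-chlorophenyl, while the step of a 1.8-fold lower number from compound 2 to compound 3 (0.26 log units; within the scatter) stays within the scatter.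

Compound 4 `CCOC(=O)c1ccc(-c2nn(Cc3ccc(OC)cc3)c3ccccc23)cc1` is not yet measured. It differs from compound 3 in one place: 4-methoxyphenyl in place of 3-methoxyphenyl on a saturated chain carbon bound to an aromatic nitrogen. Among the compounds with values here, no measured step moves the methoxy group to this position, so the only step of the same kind, a 1.8-fold lower number from compound 2 to compound 3 (0.26 log units; within the scatter), is the one that bears on it, and that step was within the scatter. The expectation for this assay is therefore no step beyond the scatter, with compound 4 estimated to land at a 1.1-fold lower number from compound 3 to compound 4 (0.05 log units; within the scatter) from compound 3. Compound 4 is expected to give about 230 nM, within a range from 100 nM to 520 nM.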

Compound 4, half-maximal inhibitory concentration: 620 nM
For compound 4 the middle estimate is 2.7-fold (0.43 log units) below the measured one; the measured number lies above the stated range.
By their numbers in this assay, from the lowest: compound 1; then compounds 3, 2 and 4 (each within the scatter of the next, the first and the last beyond it).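

In this assay, going by these compounds alone, the position of the methoxy group now makes a measurable difference: a 2.4-fold higher number from compound 3 to compound 4 (0.38 log units; beyond the scatter) is the first step between two methoxy placements to lie beyond the scatter, while a 1.3-fold higher number from compound 2 to compound 4 (0.12 log units; within the scatter) stays within it, so the 3-methoxyphenyl and 4-methoxyphenyl variants are the only placements that separate. The series also gains its first direct swap of methoxy for chloro on an aromatic carbon, with nothing else changed: a 5.2-fold higher number from compound 1 to compound 4 (0.71 log units; beyond the scatter) is the largest step in the set, and compound 1 now stands beyond the scatter from all three methoxy variants, with the strongest inhibition of the four. No information is available to explain why these placements differ.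

The compounds shown leave open whether 4-chlorophenyl is favoured specifically or whether other groups, such as 4-fluorophenyl or 4-methylphenyl, would also stay near compound 1, and whether 2-chlorophenyl and 3-chlorophenyl would follow the methoxy series. They also leave open whether the benzyl trends would hold if a carboxylic acid or an amide replaced the ethyl ester on the shared core.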